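A few compounds are considered here, and "the series" means these few. Any claim that something is new, unique, unknown or untested is made for them only; others in the source may bear on it.

Measured so far:
- compound 1, `N#CCCCc1c[nH]c2ccc(F)cc12`; an assay on isolated protein for inhibition of Myeloperoxidase (Homo sapiens), read by ELISA, with a stated time of 5 min; a lower number here means a stronger inhibitor, a higher number a weaker inhibitor: 72 nM
- compound 2, `N#CCCCc1c[nH]c2ccc(C(=O)O)cc12`; this assay: "not active" (no number reported)
- compound 3, `CCCc1c[nH]c2ccc(F)cc12`; this assay: a limit only, > 100 nM

Among the measured compounds shown here, compound 3 stands with only a limit in this assay, and compound 2 stands with no number at all, so compound 1 is the sole member of the series with a single value. For the measured compounds named here, the one step that can be sized is an at least 1.3-fold higher number from compound 1 to compound 3 (0.14 log units; that floor lies within the scatter); its floor is set by the limit of > 100 nM in this assay, at which 1 of the 3 values shown sits, so the true size of that step is open.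

The next compound is compound 4, `NCCSCCc1c[nH]c2ccc(F)cc12`. Its difference from compound 3 is (2-aminoethyl)sulfanyl in place of methyl on a saturated chain carbon, two bonds along the chain from an aromatic carbon. Going by the values given here, no measured step touches a (2-aminoethyl)sulfanyl group or any change at this place on the chain, so nothing sizes the step in this assay. Among the compounds with values here, the only guidance is that compound 3 itself sits at a limit and that the nitrile of compound 1 gave a somewhat lower number.

On that footing compound 4 is expected to fall near or somewhat above where compound 3 sits, with the step that the limit leaves unreadable from compound 3 to compound 4 carried by a wide range; the estimate for compound 4 is 300 nM, from 60 nM to 3000 nM.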

Compound 4, half-maximal inhibitory concentration: 8 nM
For compound 4 the middle estimate is 38-fold (1.57 log units) above the measured one; measured number outside the range, below it.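

In this assay, among the compounds shown here, (2-aminoethyl)sulfanyl in place of methyl on a saturated chain carbon, two bonds along the chain from an aromatic carbon, gives an at least 12-fold lower number from compound 3 to compound 4 (1.09 log units; beyond the scatter), the first step printed as beyond the scatter. Set against the cyanomethyl group, the same group gives a 9.0-fold lower number from compound 1 to compound 4 (0.95 log units; beyond the scatter), so the change can also be sized against compound 1, which has a single value. The step from compound 3 remains a floor, as compound 3 holds only a limit and no number: the limit of > 100 nM in this assay, at which 1 of the 4 values shown sits.

The group enters as a single unit, so the compounds shown do not separate the contribution of the amine from that of the sulfur or of the chain length; an ether oxygen in place of the sulfur, a hydroxyl in place of the amine, or a longer chain would each divide the question. On these data alone, whether the gain carries over when a carboxylic acid replaces the fluorine on the shared core also stays open, as compound 2 pairs that acid with the nitrile chain and has no number.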